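The compounds below may be only part of what the source reports. "The series", "measured", "known", "first", "only" and "open" are said of these compounds alone.

Working notes on the amide series, followed in a functional assay on HCT-116 cells (Homo sapiens) for antiproliferative activity, read by MTT assay, with a stated time of 72 h; a lower number here means a stronger inhibitor, a higher number a weaker inhibitor. Compound 1 `CC(C)(C)NC(=O)CCc1cccc2c1B(O)OC2` gives > 100000 nM, which is a limit and not a number. Compound 2 `O=C(CCc1cccc2c1B(O)OC2)NCc1ccccc1` gives > 100000 nM, again a limit. Among the compounds with values here, compound 3 `O=C(CCc1cccc2c1B(O)OC2)Nc1ccc(I)cc1` gives 50000 nM, the only actual number so far.

The measured steps offer little: a step that the two limits leave unreadable from compound 1 to compound 2, an at least 2.0-fold lower number from compound 1 to compound 3 (0.30 log units; that floor lies within the scatter) and an at least 2.0-fold lower number from compound 2 to compound 3 (0.30 log units; that floor lies within the scatter). All three rest on limits, and each exchanges a different kind of group on the nitrogen.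

Compound 4 `O=C(CCc1cccc2c1B(O)OC2)Nc1cccc(Br)c1` carries 3-bromophenyl in place of 4-iodophenyl on an amide-type nitrogen. Within the data shown here, no measured step swaps one halogen-bearing phenyl for another, so the size of this change in this assay has no direct precedent. The expectation therefore stays anchored on compound 3 at 50000 nM, with no direction favoured. Among the measured compounds shown here, the expected result is a 1.1-fold higher number from compound 3 to compound 4 (0.04 log units; within the scatter), with no step expected beyond the scatter.

For compound 4 the estimated value is 55000 nM, with an expected range of 22000 nM to 100000 nM.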

Compound 4, half-maximal inhibitory concentration: 1400 nM
Compound 4: the middle estimate sits 39-fold (1.59 log units) above what was measured; measured number outside the range, below it.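

In this assay, the group on the amide-type nitrogen proves able to carry a large change even between two halogen-bearing phenyl groups: 3-bromophenyl in place of 4-iodophenyl gives a 36-fold lower number from compound 3 to compound 4 (1.55 log units; beyond the scatter), although the heavy-atom count stays the same and each group holds one six-membered aromatic ring of carbon only. Against the earlier benzyl and tert-butyl groups, the same position now gives an at least 71-fold lower number from compound 2 to compound 4 (1.85 log units; beyond the scatter) and an at least 71-fold lower number from compound 1 to compound 4 (1.85 log units; beyond the scatter), both beyond the scatter. These two steps are floors and not full sizes, since compound 1 and compound 2 each stand at a limit and not at a number: the limit of > 100000 nM in this assay, at which 2 of the 4 values shown sit.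

The compounds shown do not separate the halogen from its place on the ring, as neither 3-iodophenyl nor 4-bromophenyl is among them. Going by these compounds, whether unsubstituted phenyl or 3-chlorophenyl on this nitrogen would match compound 4 also stays open.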